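Thiophene for phenyl on a dienone–coumarin triazole hybrid

The source may hold more compounds than are shown below. What is called first, only, known or untested is meant among the compounds shown, and "the series" means these compounds.

The measured compounds:
compound 1, `COc1cc(/C=C/C(=O)/C=C/c2ccccc2)ccc1OCc1cn(CCCOc2cc(=O)oc3ccccc23)nn1`, 48%
compound 2, `COc1cc(/C=C/C(=O)/C=C/c2ccco2)ccc1OCc1cn(CCCCCOc2cc(=O)oc3ccccc23)nn1`, 39%
compound 3, `COc1cc(/C=C/C(=O)/C=C/c2ccccc2)ccc1OCc1cn(CCCCOc2cc(=O)oc3ccccc23)nn1`, 36%

Of the compounds shown here, three sharing the same core have been tested in a functional assay on THP-1 cells (Homo sapiens) for inhibition, read by sulforhodamine B assay, with a stated time of 48 h, tested at 50 uM; a higher number here means more inhibition of growth at the concentration tested, a lower number less inhibition of growth. Compound 1 gives the highest of the three numbers, 48%. Compound 2, at 39%, sits within the scatter of compound 1, so the two cannot be ordered; compound 3, at 36%, lies beyond the scatter below compound 1. Going by the values given here, compound 2 and compound 3 each differ from compound 1 in more than one place, so no single-change step between measured compounds is available.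

The next compound, compound 4, `COc1cc(/C=C/C(=O)/C=C/c2cccs2)ccc1OCc1cn(CCCOc2cc(=O)oc3ccccc23)nn1`, differs from compound 1 in one place: thiophen-2-yl in place of phenyl on a double-bonded chain carbon bound to a double-bonded chain carbon. Nothing among the measured compounds isolates this exchange, and the available values give no reason to expect a change beyond the scatter in either direction. Compound 4 is therefore expected to give 44%, with a range of 30% to 58%, a step of a number 4 percentage points lower from compound 1 to compound 4 (within the scatter) that is estimated to fall within the usual scatter.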

Compound 4, percent growth inhibition at one concentration: 54%
Beside the measured number, compound 4's estimate is 10 percentage points below it; measured number inside the range.
By their numbers in this assay, from the lowest: compounds 3, 2, 1 and 4 (each within the scatter of the next, the first and the last beyond it).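

In this assay, thiophen-2-yl in place of phenyl on a double-bonded chain carbon bound to a double-bonded chain carbon gives a number 6 percentage points higher from compound 1 to compound 4 (within the scatter), the first single-change step available in this set. It shows that this position accepts a five-membered aromatic ring with one sulfur atom in place of the six-membered all-carbon ring, with no separation between the two compounds at the one concentration tested. Nothing at hand bears on what lies behind this result.

From the compounds shown here alone, it remains open whether a pyridine ring, or a phenyl carrying an amine or a carboxylic acid, would leave the number at this position equally unmoved. Going by these compounds, it is also open whether the same exchange would read alike on the longer chain that links the shared core to the far ring system.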